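Ring-closed amine in place of dimethylamino on the shared core

The compounds below may be only part of what the source reports. "The series", "measured", "known", "first", "only" and "open" are said of these compounds alone.

Of the compounds shown here, three of a shared core have been measured in an assay on RBE4 cells for inhibition of Monocarboxylate transporter 1 (Rattus norvegicus), with a stated time of 15 min; a higher number here means a weaker inhibitor, a lower number a stronger inhibitor. Compound 1 `N#C/C(=C\c1ccc(Cl)cc1)C(=O)O` gives 500 nM, and compound 2 `N#C/C(=C\c1ccc(Br)cc1)C(=O)O` gives 500 nM; the step of no change at the digits printed from compound 1 to compound 2 (within the scatter). Compound 3 `CN(C)c1ccc(/C=C(\C#N)C(=O)O)cc1` gives 140 nM, the lowest number of the three, reached by a 3.6-fold lower number from compound 1 to compound 3 (0.55 log units; beyond the scatter) and by a 3.6-fold lower number from compound 2 to compound 3 (0.55 log units; beyond the scatter). Compound 4 `N#C/C(=C\c1ccc(N2CCCC2)cc1)C(=O)O` differs from compound 3 only in that (pyrrolidin-1-yl in place of dimethylamino on an aromatic carbon). For the measured compounds named here, no measured step exchanges one amine for another, so none bears on it directly; the measured steps only show that the group at this place matters. A small step at most is expected in this assay, a 1.3-fold lower number from compound 3 to compound 4 (0.10 log units; within the scatter). For compound 4 the estimate is 110 nM, within 50 nM to 250 nM.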

Compound 4, half-maximal inhibitory concentration: 70 nM
Compound 4: the middle estimate sits 1.6-fold (0.20 log units) above what was measured; low and high end bracket the measured number.
By their numbers in this assay, from the lowest: compounds 4 and 3 (each within the scatter of the next); then compounds 1 and 2 (each within the scatter of the next).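

In this assay, for the compounds shown here, the first exchange of one amine for another gives a 2.0-fold lower number from compound 3 to compound 4 (0.30 log units; within the scatter), so closing dimethylamino into the ring of pyrrolidin-1-yl does not separate the two amines. The larger ring-closed group also keeps the distance from the halogens, with a 7.1-fold lower number from compound 1 to compound 4 (0.85 log units; beyond the scatter) and a 7.1-fold lower number from compound 2 to compound 4 (0.85 log units; beyond the scatter). Across these four compounds, both amines give lower numbers than both halogens, and none goes against this. Going by these compounds, a six-membered piperidin-1-yl or morpholin-4-yl group, or longer chains on the nitrogen, remain open. Nothing available gives a reason for these steps.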